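Cytotoxicity notes on a benzimidazole thioether amide series

The source may hold more compounds than are shown below. What is called first, only, known or untested is meant among the compounds shown, and "the series" means these compounds.

Measured so far:
compound 1 `COc1ccc(Cn2c(SC(C)C(=O)Nc3ccc(C)cc3Cl)nc3ccccc32)cc1` — > 75000 nM
compound 2 `COc1ccc(-n2c(SC(C)C(=O)Nc3nc(C)c(Br)cc3Br)nc3ccccc32)cc1` — 9700 nM
compound 3 `COc1ccc(-n2c(SC(C)C(=O)Nc3nc(C)cc(Cl)n3)nc3ccccc32)cc1` — "not determined" (no result reported)

In an ADME assay on Vero cells (Chlorocebus sabaeus) for cytotoxicity, read by MTT assay, with a stated time of 24 h (on this read-out higher numbers stand for lower toxicity in this test and lower numbers for higher toxicity in this test), compound 1 gives only a limit, > 75000 nM; this is the limit described in the limit of > 75000 nM in this assay, at which 1 of the 3 values shown sits. In this assay compound 2 gives 9700 nM. For compound 3 no number was obtained in this assay, so it stands nowhere on the scale shown here, and no measured step leads from it to any other compound.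

Compound 4 `COc1ccc(-n2c(SC(C)C(=O)Nc3ncc(C(F)(F)F)cc3Cl)nc3ccccc32)cc1` differs from compound 3 in one place: 3-chloro-5-(trifluoromethyl)pyridin-2-yl in place of 4-chloro-6-methylpyrimidin-2-yl on an amide-type nitrogen. With no value for compound 3, the size and direction of this step in this assay cannot be stated; the only comparable single-number result is that of compound 2, whose core arrangement compound 4 shares apart from the amide substituent.

Compound 4 is therefore expected to give a value of about 15000 nM in this assay, estimated within 4000 nM to 75000 nM, with a fair chance that only a limit is reported.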

Compound 4, half-maximal cytotoxic concentration: 9200 nM
Compound 4: the middle estimate sits 1.6-fold (0.21 log units) above what was measured; the measured number falls inside the stated range.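

In this assay, for the compounds shown here, 3-chloro-5-(trifluoromethyl)pyridin-2-yl in place of 3,5-dibromo-6-methylpyridin-2-yl on the amide-type nitrogen gives a 1.1-fold lower number from compound 2 to compound 4 (0.02 log units; within the scatter), the first step that can be read at this place. The two groups thus cannot be told apart in this test, even though the substituents on the pyridin-2-yl ring differ: two bromines and a methyl in one, a chlorine and a trifluoromethyl in the other. Nothing at hand accounts for this match, and one step at one place supports no wider rule for the series.

From the compounds shown here alone, compound 3 carries no number, so its step to compound 4 cannot be read, and it remains open whether the 4-chloro-6-methylpyrimidin-2-yl group, or a pyridin-2-yl ring bearing a carboxylic acid or a dimethylamino group, would leave this assay unchanged at this place. Compound 1 gives only a limit, > 75000 nM, and it differs from compound 2 and compound 4 in more than one place, so it offers no comparison here.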